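Alkynyl carbamates: ester chain length and terminal amine

The source may hold more compounds than are shown below. What is called first, only, known or untested is meant among the compounds shown, and "the series" means these compounds.

Measured in a functional assay on the whole organism for agonist activity, with Mus musculus as the target; on this read-out higher numbers stand for an effect only at larger amounts of compound and lower numbers for an effect already at smaller amounts:
compound 1 `COC(=O)N(C)C(C)C#CCN1CCCC1` — 9.7 mg/kg
compound 2 `COC(=O)N(C)C(C)C#CCn1ccnc1` — 6.6 mg/kg
compound 3 `CCOC(=O)N(C)C(C)C#CCN1CCCC1` — only a limit of this assay, > 100 mg/kg

Compound 2 differs from compound 1 by 1H-imidazol-1-yl in place of pyrrolidin-1-yl on a saturated chain carbon bound to a triple-bonded carbon. The step in this assay is a 1.5-fold lower number from compound 1 to compound 2 (0.17 log units; within the scatter). The two cores differ by methyl in place of hydrogen on a saturated chain carbon bound to an oxygen next to a carbonyl group. The step for that change is an at least 10-fold higher number from compound 1 to compound 3 (1.01 log units; beyond the scatter). Compound 3 sits at the limit of > 100 mg/kg in this assay, at which 1 of the 3 values shown sits, so its value is a limit and not a number.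

Compound 4 `CCOC(=O)N(C)C(C)C#CCn1ccnc1` has not been measured in this assay. It differs from compound 3 by 1H-imidazol-1-yl in place of pyrrolidin-1-yl on a saturated chain carbon bound to a triple-bonded carbon; the place is the same as for the change from compound 1 to compound 2, so this is the same change applied to the ethoxycarbonyl core. From the step of a 1.5-fold lower number from compound 1 to compound 2 (0.17 log units; within the scatter), the expected step is a number no higher from compound 3 to compound 4 (the limit leaves the size open), a change that stays within the scatter. Because compound 3 gives only a limit, > 100 mg/kg, compound 4 is expected most likely to give only a limit as well. The estimate for compound 4 is 100 mg/kg, with a range from 40 mg/kg to 300 mg/kg.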

Compound 4, dose for half-maximal effect: > 100 mg/kg
Compound 4: a limit, no number; the forecaster's own chance of this, stated with the estimate: 70%; the middle value sits exactly at the limit.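

In this assay compound 4 gives > 100 mg/kg, which is a limit and not a number, so the step for 1H-imidazol-1-yl in place of pyrrolidin-1-yl on the ethoxycarbonyl core cannot be read. Methyl in place of hydrogen on a saturated chain carbon bound to an oxygen next to a carbonyl group gives an at least 15-fold higher number from compound 2 to compound 4 (1.18 log units; beyond the scatter), so this change carries over in direction from the core of compound 1 to the core of compound 2. Its size on the two cores cannot be compared, and carrying the change over is shown only as far as direction: the same change on two cores in this assay, an at least 10-fold higher number (1.01 log units; beyond the scatter) from compound 1 to compound 3 and an at least 15-fold higher number (1.18 log units; beyond the scatter) from compound 2 to compound 4; the limit leaves it open whether they differ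

From the compounds shown here alone, how far the ethoxycarbonyl compounds lie past the limit stays open, as does whether a longer ester chain such as propyl gives a number at all. Also open, going by these compounds, is whether piperidin-1-yl or dimethylamino in place of pyrrolidin-1-yl would stay within the scatter of compound 1, as 1H-imidazol-1-yl does.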